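Swapping a Sulfonamide for an Amide on a Cytotoxic Core

The source may report more compounds than this note shows. Statements on the series, on what has been measured and on what is new or still open speak of the compounds shown alone.

Of the compounds shown here, two sharing one core have been tested in a functional assay on SK-MEL-28 cells (Homo sapiens) for cytotoxicity, read by MTT assay; a higher number here means a weaker inhibitor, a lower number a stronger inhibitor. Compound 1 `O=S(=O)(NCCNc1nccc(-c2c(-c3cccc(F)c3)nc3sccn23)n1)c1cccc(F)c1` carries a ((3-fluorophenyl)sulfonyl)amino group, and in this assay compound 1 gives 18300 nM. Compound 2 `Cc1ccc(S(=O)(=O)NCCCNc2nccc(-c3c(-c4cccc(F)c4)nc4sccn34)n2)cc1` carries instead a (((4-methylphenyl)sulfonyl)amino)methyl group on a saturated chain carbon, two bonds along the chain from a nitrogen on an aromatic ring, and in this assay compound 2 gives 9500 nM. Among the compounds with values here, the step of a 1.9-fold lower number from compound 1 to compound 2 (0.28 log units; within the scatter) is the only measured comparison. Compound 2 therefore has the lower of the two numbers, yet it sits within the scatter of compound 1, so the two cannot be told apart.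

Compound 3 `O=C(NCCCNc1nccc(-c2c(-c3cccc(F)c3)nc3sccn23)n1)c1ccc(F)cc1` keeps the chain of compound 2 and alters the group on its amine nitrogen: (4-fluorophenyl)carbonyl in place of (4-methylphenyl)sulfonyl on an amine nitrogen. Within the data shown here, no measured step replaces a sulfonyl with a carbonyl; the step of a 1.9-fold lower number from compound 1 to compound 2 (0.28 log units; within the scatter) changed the aryl sulfonyl and the chain together and stayed within the scatter, so it offers little guidance. The expected step in this assay is a 1.1-fold higher number from compound 2 to compound 3 (0.02 log units; within the scatter), nothing beyond the scatter. For compound 3 the estimated value is 10000 nM, with a range from 3000 nM to 35000 nM.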

Compound 3, half-maximal inhibitory concentration: > 20000 nM
Compound 3: a limit, no number; the forecaster's own chance of this, stated with the estimate: 10%; middle value at least 2.0-fold (0.30 log units) away from the limit.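

In this assay, the value for compound 3 is a limit of the assay and not a number: the limit of > 20000 nM in this assay, at which 1 of the 3 values shown sits. Even so, that limit is enough to give the first change at this position that stands clear of the scatter: on an amine nitrogen, (4-fluorophenyl)carbonyl in place of (4-methylphenyl)sulfonyl gives an at least 2.1-fold higher number from compound 2 to compound 3 (0.32 log units; beyond the scatter), so on this chain the amide is a weaker inhibitor than the sulfonamide. The other comparison, an at least 1.0-fold higher number from compound 1 to compound 3 (0.03 log units; that floor lies within the scatter), alters the chain as well and gives only a floor, so it settles no order between the two compounds.

On these data alone, the true size of the loss stays unknown, and the step cannot say how much of it belongs to the carbonyl replacing the sulfonyl and how much to the fluorine replacing the methyl on the aromatic ring, since both changed together. Also open, as far as these compounds go, is how a (4-methylphenyl)carbonyl group, which would separate those two changes, or a plain amine at the end of this chain would read in this assay.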